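Methyl step on the compound 3 amide chain

A few compounds are considered here, and "the series" means these few. Any claim that something is new, unique, unknown or untested is made for them only; others in the source may bear on it.

Measured in a functional assay on HeLa cells (Homo sapiens) for antiproliferative activity, read by MTT assay, with a stated time of 72 h (a higher number here means a weaker inhibitor, a lower number a stronger inhibitor), so far:
- compound 1 `CC/C=C/C(=O)Nc1cccc(Oc2nc(Nc3ccn(C)n3)nc3c2CSCC3)c1` gives > 50000 nM as a limit
- compound 2 `CC(C)/C=C/C(=O)Nc1cccc(Oc2nc(Nc3ccn(C)n3)nc3c2CSCC3)c1` gives 40100 nM as a number
- compound 3 `CC/C=C/C(=O)Nc1cccc(Oc2nc(Nc3cccc(OC)c3)nc3c2CSCC3)c1` gives 27200 nM as a number

Compound 3 at 27200 nM and compound 2 at 40100 nM lie within the scatter of each other. Going by the values given here, the only other value, for compound 1, is a limit.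

Compound 4 `COc1cccc(Nc2nc3c(c(Oc4cccc(NC(=O)/C=C/C(C)C)c4)n2)CSCC3)c1` differs from compound 3 by one change (methyl in place of hydrogen on a saturated chain carbon bound to a double-bonded chain carbon and a saturated chain carbon), ethyl to isopropyl. Among the compounds with values here, the same change appears in an at least 1.2-fold lower number from compound 1 to compound 2 (0.09 log units; that floor lies within the scatter) and is the closest precedent. The other measured step, 3-methoxyphenyl in place of 1-methyl-1H-pyrazol-3-yl, is an at least 1.8-fold lower number from compound 1 to compound 3 (0.26 log units; that floor lies within the scatter) and only sets the starting series for compound 4. Both steps start from the limit of > 50000 nM in this assay, at which 1 of the 3 values shown sits, and so give floors, not sizes.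

With an at least 1.2-fold lower number from compound 1 to compound 2 (0.09 log units; that floor lies within the scatter) as the precedent, no change beyond the scatter is expected in this assay here. The expected result is a 1.2-fold lower number from compound 3 to compound 4 (0.07 log units; within the scatter) in this estimate. For compound 4 the estimated value is 23000 nM with an expected range from 10000 nM to 48000 nM in the same read-out.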

Compound 4, half-maximal inhibitory concentration: > 50000 nM
Compound 4 was reported as a limit (the forecaster's own chance of this, stated with the estimate: 10%); middle value at least 2.1-fold (0.33 log units) away from the limit.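

In this assay, ethyl to isopropyl on the amide chain of the 3-methoxyphenyl series gives an at least 1.8-fold higher number from compound 3 to compound 4 (0.26 log units; that floor lies within the scatter), so the methyl shows no lower number here, and the direction seen with the 1-methyl-1H-pyrazol-3-yl series is not confirmed: the same change on two cores in this assay, an at least 1.2-fold lower number (0.09 log units; that floor lies within the scatter) from compound 1 to compound 2 and an at least 1.8-fold higher number (0.26 log units; that floor lies within the scatter) from compound 3 to compound 4; the limit leaves it open whether they differ

With isopropyl on the chain, 3-methoxyphenyl in place of 1-methyl-1H-pyrazol-3-yl gives an at least 1.2-fold higher number from compound 2 to compound 4 (0.09 log units; that floor lies within the scatter), so the aryl change does not carry a lower number over from the ethyl chain: the same change on two cores in this assay, an at least 1.8-fold lower number (0.26 log units; that floor lies within the scatter) from compound 1 to compound 3 and an at least 1.2-fold higher number (0.09 log units; that floor lies within the scatter) from compound 2 to compound 4; the limit leaves it open whether they differ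

Neither comparison yields a size, and limits now account for much of the set: the limit of > 50000 nM in this assay, at which 2 of the 4 values shown sit.

Left open is the size of the methyl step on either core. Also open, from the compounds shown here alone, is whether a dimethylamino group at the chain end, in place of ethyl or isopropyl, would move the number beyond the scatter from compound 3.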